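A few compounds are considered here, and "the series" means these few. Any claim that something is new, unique, unknown or untested is made for them only; others in the source may bear on it.

Measured so far in an ADME assay on WI-38 cells (Homo sapiens) for cytotoxicity, read by sulforhodamine B assay, with a stated time of 24 h (a lower number here means a stronger inhibitor, a higher number a weaker inhibitor), are two compounds
- compound 1 `O=C1Nc2ccc(S(=O)(=O)N3CCOCC3)cc2/C1=N/c1cccc(C(F)(F)F)c1` with 226000 nM
- compound 2 `CC(=O)N/N=C1\C(=O)Nc2ccc(S(=O)(=O)N3CCOCC3)cc21` with 325000 nM

Compound 2 has only compound 1 to stand against, and the measured step between them is a 1.4-fold higher number from compound 1 to compound 2 (0.16 log units; within the scatter) so the two cannot be ranked. That step put acetamido in place of 3-(trifluoromethyl)phenyl on a double-bonded nitrogen.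

Going by the values given here, the next compound, compound 3 `O=C1Nc2ccc(S(=O)(=O)N3CCOCC3)cc2/C1=N/Nc1ccccc1` starts from compound 2 and has phenyl in place of acetyl on an amine nitrogen as its one structural change. Compound 3 therefore carries an aromatic ring in this group, as compound 1 does, although without trifluoromethyl. Among the compounds with values here, the single measured step is the only guide here, and it is thin evidence. It exchanged an aromatic group for a non-aromatic one and stayed within the scatter, so no step beyond the scatter is expected in this assay for this change. The expected size is a 1.4-fold lower number from compound 2 to compound 3 (0.15 log units; within the scatter) in this estimate. For compound 3 the estimated value is 230000 nM with an expected range from 100000 nM to 450000 nM in all.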

Compound 3, half-maximal inhibitory concentration: 262000 nM
Beside the measured number, compound 3's estimate is 1.1-fold (0.06 log units) below it; the measured number falls inside the stated range.
By their numbers in this assay, from the lowest: compounds 1, 3 and 2 (each within the scatter of the next).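

Putting phenyl in place of acetyl on an amine nitrogen gives a 1.2-fold lower number from compound 2 to compound 3 (0.09 log units; within the scatter) in this assay, so a six-membered aromatic ring of carbon only and a small acetyl group cannot be told apart at this place. Going by these compounds alone, compound 3 also differs from compound 1 in one place, and that change gives a 1.2-fold higher number from compound 1 to compound 3 (0.06 log units; within the scatter) and so adds a second comparison: across compounds 1, 2 and 3, each of the three groups carried on this nitrogen gives numbers within the scatter of the other two, where the earlier compounds offered only a single step. Nothing available here accounts for these numbers or says what lies behind them.

These three compounds do not show whether a different kind of group on this nitrogen, such as a carboxylic acid, an amine or a longer chain, would give a step beyond the scatter. They also share one core, so they leave open whether a change elsewhere in the core would move the number in this assay more than any change at this place has.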